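Furan-2-yl in Place of 4-Fluorophenyl: What to Expect

The source may report more compounds than this note shows. Statements on the series, on what has been measured and on what is new or still open speak of the compounds shown alone.

compound 1 `Cc1nc(N)sc1CCCN/C(N)=N/C(=O)N[C@@H](C)c1ccccc1` — 23.4 nM
compound 2 `Cc1nc(N)sc1CCCN/C(N)=N/C(=O)NC(C)c1ccc(F)cc1` — 23.4 nM

In a functional assay on Right cardiac atrium for agonist activity at histamine H2 receptor (Cavia porcellus), with a stated time of 30 min, in the presence of a further agent that is not named here (a higher number here means that more compound is needed for the effect, a lower number that less compound is needed), compound 1 gives 23.4 nM and compound 2 gives 23.4 nM, so compound 2 stands level with compound 1 within the scatter. Compound 3 `Cc1nc(N)sc1CCCN/C(N)=N/C(=O)NC(C)c1ccco1` differs from compound 2 by furan-2-yl in place of 4-fluorophenyl on a saturated chain carbon bound to an amide-type nitrogen and a saturated chain carbon. Among the compounds with values here, no step between measured compounds covers this change, so the expectation rests on the two values alone. A modest weakening is expected, with the step of a 1.7-fold higher number from compound 2 to compound 3 (0.23 log units; within the scatter) judged close to the edge of the scatter. Compound 3 is estimated to give 40 nM, within a range from 15 nM to 120 nM.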

Compound 3, half-maximal effective concentration: 9.77 nM
Beside the measured number, compound 3's estimate is 4.1-fold (0.61 log units) above it, outside the stated range (below it).
By their numbers in this assay, from the lowest: compound 3; then compounds 1 and 2 (each within the scatter of the next).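

Furan-2-yl in place of 4-fluorophenyl brings a 2.4-fold lower number from compound 2 to compound 3 (0.38 log units; beyond the scatter) in this assay and so gives the first change at this place that lies beyond the scatter. The wider swap of 1-(furan-2-yl)ethyl for 1-phenylethyl on the amide-type nitrogen brings a 2.4-fold lower number from compound 1 to compound 3 (0.38 log units; beyond the scatter) of the same size. This place therefore does respond to the ring it carries, and a five-membered aromatic ring with one hetero atom gives the lower number here. No measurement shown accounts for the step. On these data alone, whether a thiophen-2-yl or pyridin-2-yl ring would match furan-2-yl remains open, as does the effect of a hydrogen in place of the methyl on this carbon.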